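The source may report more compounds than this note shows. Statements on the series, on what has been measured and on what is new or still open speak of the compounds shown alone.

Measured compounds:
- compound 1, `Cc1ccc(C(=O)N[C@@H](C(=O)N2CCC(c3ccc(Cl)cc3)CC2)C(C)C)cc1`: 25 nM
- compound 2, `CC(C)C(NC(=O)c1ccccc1)C(=O)N1CCN(c2ccc(Cl)c(Cl)c2)CC1`: 375 nM

Compound 1 stands lowest of the two numbers in an assay on THP-1 cells for displacement of a labelled ligand from C-C chemokine receptor type 1 (Homo sapiens); on this read-out higher numbers stand for weaker inhibition and lower numbers for stronger inhibition. Compound 2, with the values in this assay shown beside it, sits at a higher number, and the gap between the two lies beyond the scatter; since the two structures differ in more than one place, nothing more than that can be read from the pair.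

The step of interest runs from compound 1 to compound 3, `CC(C)[C@@H](NC(=O)c1ccc(F)c(F)c1)C(=O)N1CCC(c2ccc(Cl)cc2)CC1`, which has not yet been measured in this assay. The change is 3,4-difluorophenyl in place of 4-methylphenyl on a carbonyl carbon. Among the compounds with values here, no measured pair in this set isolates such a change, so the size of the step can only be guessed. A shift of this kind, at the carbonyl carbon whose other neighbour is the amide-type nitrogen, is expected to cost little or nothing: the step from compound 1 to compound 3 is expected to be a 2.0-fold higher number from compound 1 to compound 3 (0.30 log units; within the scatter), towards a somewhat higher number, if anything beyond the scatter at all. On that basis compound 3 is estimated at 50 nM, with a range from 15 nM to 170 nM.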

Compound 3, half-maximal inhibitory concentration: 14 nM
For compound 3 the middle estimate is 3.6-fold (0.55 log units) above the measured one; measured number below the stated range.
By their numbers in this assay, from the lowest: compounds 3 and 1 (each within the scatter of the next); then compound 2.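

In this assay, 3,4-difluorophenyl in place of 4-methylphenyl on a carbonyl carbon gives a 1.8-fold lower number from compound 1 to compound 3 (0.25 log units; within the scatter) and so leaves the two compounds indistinguishable on this read-out. Within the data shown here, this is the first pair in the set that differs in one place, and it shows that this position can carry either of these two substituted phenyl groups, one with a methyl group and the other with two fluorine atoms, without a step beyond the scatter. No measurement bearing on the result accompanies these numbers, so the data offer no account of it.

Both groups are six-membered aromatic rings of carbon only with no hydrogen-bond donors or acceptors, so the compounds shown leave open whether the position would accept a pyridine ring, or a phenyl ring carrying an amine or a carboxylic acid, with a similar result. They also leave open what a longer chain in place of the ring would do, and how far the result for this one pair extends to other substituents on the phenyl ring, such as a single fluorine atom or a methoxy group.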